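The source may report more compounds than this note shows. Statements on the series, on what has been measured and on what is new or still open speak of the compounds shown alone.

Working notes on the series, read in an ADME assay on HFF cells (Homo sapiens) for cytotoxicity, read by neutral red uptake; on this read-out lower numbers stand for higher toxicity in this test and higher numbers for lower toxicity in this test. Compound 1 (`Nc1nc2c(ncn2/C=C2\C[C@@H]2[C@H](O)CO)c(=O)[nH]1`) gives > 300000 nM as its result, which is a limit of the assay and not a number. Compound 3 (`Nc1nc2c(ncn2/C=C2/CC2(CO)CO)c(=O)[nH]1`) gives > 100000 nM as its result, which is also a limit of the assay and not a number. Compound 2 (`Nc1ncnc2c1ncn2/C=C1\C[C@H]1[C@H](O)CO`) is the only one of the three with a measured number, at 194000 nM in this assay as read by its half-maximal cytotoxic concentration. Compound 1 therefore stands at a limit, with no exact position on the scale.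

Compound 4 (`Nc1nc2c(ncn2/C=C2\C[C@H]2[C@H](O)CO)c(=O)[nH]1`) is the next to be read against compound 1. The change is the two compounds have the same atoms and bonds and differ only in configuration as drawn: 1 of 3 stereo elements differ; a stereocentre at a saturated ring carbon is drawn S in compound 1 and R in compound 4 and nothing leaves or enters: a stereocentre at a saturated ring carbon is drawn S in compound 1 and R in compound 4. Within the data shown here, no measured pair in the set shows what such a change does. Among the measured compounds shown here, the expectation rests on the values themselves, with compound 2 at 194000 nM as the sole number and no compound yet showing a much lower one. A shift beyond the usual scatter in this assay is not expected, in either direction, so the expected change is a number no higher from compound 1 to compound 4 (the limit leaves the size open) and no more. For compound 4 the estimated value is 300000 nM with an expected range from 130000 nM to 600000 nM and a good chance of a limit instead of a number.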

Compound 4, half-maximal cytotoxic concentration: > 300000 nM
Compound 4: a limit, no number; the forecaster's own chance of this, stated with the estimate: 60%; the middle value lies on the limit itself.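

Compound 1 and compound 4 both give a limit of the assay and not a number, so no step can be read between them. The compounds shown leave open whether the configuration at that saturated ring carbon has any effect on the result in this assay.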